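The source may hold more compounds than are shown below. What is called first, only, known or untested is meant among the compounds shown, and "the series" means these compounds.

In a toxicity assay on THP-1 cells (Homo sapiens) for inhibition (on this read-out higher numbers stand for lower toxicity in this test and lower numbers for higher toxicity in this test), compound 1 `COc1ccc(-c2cnc(NC(=O)c3cccc(O)c3)n2C)cc1` reaches only a limit of the assay rather than a number, namely > 100000 nM. The two other compounds measured alongside it behave in the same way. Compound 2 `COc1ccccc1-c1cnc(NC(=O)c2ncc[nH]2)n1C` stops at a limit of > 50000 nM. Compound 3 `Cn1c(-c2ccccc2)cnc1NC(=O)c1cc(-c2ccccn2)[nH]n1` likewise gives only a limit, > 50000 nM. Going by the values given here, compound 1 thus sits at the limit of > 100000 nM in this assay, at which 1 of the 3 values shown sits, while the other two sit at the limit of > 50000 nM in this assay, at which 2 of the 3 values shown sit; none of the three yields a number, and no step between two measured values can be read off from this set.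

Compound 4 `COc1ccc(C(=O)Nc2ncc(-c3ccc(OC)cc3)n2C)cc1` differs from compound 1 in a single place: 4-methoxyphenyl in place of 3-hydroxyphenyl on a carbonyl carbon. With all three measured compounds resting at limits, the step expected in this assay from compound 1 to compound 4 is none beyond the scatter, a number no higher from compound 1 to compound 4 (the limit leaves the size open). Compound 4 is therefore estimated to show 100000 nM, with a range from 30000 nM to 300000 nM, and it is expected that the assay will most likely once again report only a limit and no number for compound 4.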

Compound 4, half-maximal cytotoxic concentration: > 100000 nM
Compound 4: only a limit was reported (the forecaster's own chance of this, stated with the estimate: 80%); the middle value lies on the limit itself.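

In this assay compound 1 and compound 4 both end at a limit of the assay rather than a number, so no step can be read between them. The compounds shown leave open whether 4-methoxyphenyl in place of 3-hydroxyphenyl on a carbonyl carbon alters this read-out at all, and at what concentration any of them would reach a measurable value.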